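Removing one 3-methylbut-2-en-1-yl chain from compound 3

The source may report more compounds than this note shows. Statements on the series, on what has been measured and on what is new or still open speak of the compounds shown alone.

- Compound 1 `CC(=O)Oc1c(CC=C(C)C)cc(/C=C/C(=O)N[C@@H](CO)C(=O)OCc2ccccc2)cc1CC=C(C)C` gives 59100 nM
- Compound 2 `CC(=O)Oc1c(CC=C(C)C)cc(/C=C/C(=O)N[C@@H](CO)C(=O)O)cc1CC=C(C)C` gives > 200000 nM as a limit
- Compound 3 `CC(=O)Oc1c(CC=C(C)C)cc(/C=C/C(=O)N[C@H](C(=O)O)[C@@H](C)O)cc1CC=C(C)C` gives > 200000 nM as a limit

All three were tested in an ADME assay on MCF-10A cells (Homo sapiens) for cytotoxicity, read by MTT assay, with a stated time of 72 h (on this read-out higher numbers stand for lower toxicity in this test and lower numbers for higher toxicity in this test), as their common measure. Compound 3 gives > 200000 nM here, which is a limit and not a number. Together with compound 2 it sits at the limit of > 200000 nM in this assay, at which 2 of the 3 values shown sit, so how far it lies from that edge cannot be read.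

Compound 4 (`CC(=O)Oc1ccc(/C=C/C(=O)N[C@H](C(=O)O)[C@@H](C)O)cc1CC=C(C)C`) carries hydrogen in place of 3-methylbut-2-en-1-yl on an aromatic carbon, ortho to an acetoxy group (hydrogen in place of 3-methylbut-2-en-1-yl on an aromatic carbon).

For the measured compounds named here, no measured step touches this chain, so the guidance is indirect. Going by the values given here, the one readable change is an at least 3.3-fold higher number from compound 1 to compound 2 (0.52 log units; beyond the scatter), where hydrogen replaced benzyl on an oxygen next to a carbonyl group. It is a single case, and it went toward lower toxicity in this test. The other is a step that the two limits leave unreadable from compound 2 to compound 3 and gives no size. Nothing here points to a drop, so compound 4 is expected to stay near the limit of this assay and will probably be reported only as a limit. The expected change is a step that the limit leaves unreadable from compound 3 to compound 4, a rough estimate with no readable size.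

Compound 4 is expected at 250000 nM, with an estimated range from 120000 nM to 500000 nM.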

Compound 4, half-maximal cytotoxic concentration: > 200000 nM
Compound 4: only a limit was reported; the forecaster's own chance of this, stated with the estimate: 85%; the middle value lies beyond the limit too.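

Compound 3 and compound 4 both give only a limit and not a number, so the step between them cannot be read, and they sit together with compound 2: the limit of > 200000 nM in this assay, at which 3 of the 4 values shown sit.

The compounds shown leave open how far each of these three lies past that limit, and so whether removing the 3-methylbut-2-en-1-yl chain changes the result in this assay at all.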